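A few compounds are considered here, and "the series" means these few. Any claim that something is new, unique, unknown or untested is made for them only; others in the source may bear on it.

Working notes on the series. Compound 1 `O=[N+]([O-])c1ccc(C2=NOC(c3ccc(N4CCN(Cc5ccc(F)nc5)CC4)cc3)C2)o1`, compound 2 `O=[N+]([O-])c1ccc(C2=NOC(c3ccc(N4CCN(Cc5ccncc5)CC4)cc3)C2)o1` and compound 3 `O=[N+]([O-])c1ccc(C2=NOC(c3ccc(-c4ccccn4)cc3)C2)o1` share one core and were run in an ADME assay on HeLa cells (Homo sapiens) for cytotoxicity, read by MTT assay, with a stated time of 96 h; on this read-out lower numbers stand for stronger inhibition and higher numbers for weaker inhibition. In this assay compound 1 gives only a limit, > 50000 nM. In this assay compound 2 likewise reaches only a limit, > 50000 nM. In this assay compound 3 also stops at a limit, > 50000 nM. Compound 2 thus stands at the limit on which every value here sits, (the limit of > 50000 nM in this assay, at which 3 of the 3 values shown sit). For the measured compounds named here, the one step between measured pairs, a step that the two limits leave unreadable from compound 1 to compound 2, runs between two limits and has no readable size. Compound 4 `O=[N+]([O-])c1ccc(C2=NOC(c3ccc(N4CCN(Cc5cccnc5)CC4)cc3)C2)o1` is not yet measured; it differs from compound 2 by pyridin-3-yl in place of pyridin-4-yl on a saturated chain carbon bound to an amine nitrogen in a ring. Going by the values given here, the only measured step that bears on this change, a step that the two limits leave unreadable from compound 1 to compound 2, carries no size, and no value in the set falls inside the measured range, so no step beyond the scatter is expected in this assay: the estimated step is a step that the limit leaves unreadable from compound 2 to compound 4. Compound 4 is expected to give about 100000 nM, within 40000 nM to 300000 nM, most probably again as a limit only.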

Compound 4, half-maximal inhibitory concentration: > 50000 nM
Compound 4 ended at the assay's limit (the forecaster's own chance of this, stated with the estimate: 85%); the middle value lies beyond the limit too.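

Compound 4, like compound 1 and compound 2, stops at a limit in this assay, so no step among these three compounds can be read: the limit of > 50000 nM in this assay, at which 4 of the 4 values shown sit.

The compounds shown leave open whether pyridin-3-yl, pyridin-4-yl and 6-fluoropyridin-3-yl differ at all in this assay.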